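Piperidin-4-yl replaces 4-cyanophenyl in compound 3

The source may hold more compounds than are shown below. What is called first, only, known or untested is meant among the compounds shown, and "the series" means these compounds.

In a physicochemical assay for lipophilicity, read by HPLC, measured as chromatographic lipophilicity, at pH 7.4 (a higher number here means a more lipophilic compound, a lower number a more polar compound), compound 2 (`COc1cccc(NC(=O)c2nnn(Cc3ccc(C#N)cc3)c2N)c1`) is the higher of the two measured compounds at 2.3, while compound 1 (`COc1cccc(NC(=O)c2nnn(Cc3ccc([S+](C)[O-])cc3)c2N)c1`) gives 1.3. Compound 3 (`COc1cccc(NC(=O)c2nnn(CC3CCNCC3)c2N)c1`) brings one change: piperidin-4-yl in place of 4-cyanophenyl on a saturated chain carbon bound to an aromatic nitrogen. For the measured compounds named here, only one measured step bears on it, the modest a number 1.00 log units higher from compound 1 to compound 2 (beyond the scatter). Going by the values given here, that step shows that a change in this part of the structure can move the reading beyond the scatter, but no measured compound carries a non-aromatic ring here. A downward move larger than that step is expected, an estimated a number 1.60 log units lower from compound 2 to compound 3 (beyond the scatter). The expected value for compound 3 is 0.7, in an estimated range of 0 to 1.4.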

Compound 3, distribution coefficient: 0.6
For compound 3 the middle estimate is 0.10 log units above the measured one; the range from low to high includes it.
By their numbers in this assay, from the lowest: compound 3; then compound 1; then compound 2.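

In this assay, for the compounds shown here, the earlier compounds showed only a change on the aromatic carbon, with the aromatic ring kept. Compound 3 shows that replacing the whole ring on the saturated chain carbon also moves the reading beyond the scatter, with a number 1.70 log units lower from compound 2 to compound 3 (beyond the scatter) and a number 0.70 log units lower from compound 1 to compound 3 (beyond the scatter). Nothing measured here accounts for this shift.

The compounds shown do not separate the loss of the aromatic ring from the presence of the ring nitrogen. A cyclohexyl ring, or a piperidine with a methyl on its nitrogen, would bear on that question.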